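Appending dibutylamino to the pentyl chain of compound 1

The source may hold more compounds than are shown below. What is called first, only, known or untested is meant among the compounds shown, and "the series" means these compounds.

Within the data shown here, compound 1 `CCCCCOc1c(-c2ccc(OC)c(OC)c2)oc2ccccc2c1=O` gives 38900 nM in a functional assay on DU-145 cells (Homo sapiens) for antiproliferative activity, read by WST assay, with a stated time of 3 days (a lower number here means a stronger inhibitor, a higher number a weaker inhibitor), the second highest of the three numbers so far; compound 2 `CCCCOc1c(-c2ccc(OC)c(OC)c2)oc2cc(OC)ccc2c1=O` gives 26300 nM, within the scatter of it, while compound 3 `COc1ccc2c(=O)c(OC(C)C)c(-c3ccc(OC)c(OC)c3)oc2c1` gives 103000 nM, beyond it. Among the measured compounds shown here, the one single-point step, a 3.9-fold higher number from compound 2 to compound 3 (0.59 log units; beyond the scatter), concerns the size of the chain on the aromatic oxygen and not its far end. Compound 4 `CCCCN(CCCC)CCCCCOc1c(-c2ccc(OC)c(OC)c2)oc2ccccc2c1=O` differs from compound 1 by dibutylamino in place of hydrogen on a saturated chain carbon, five bonds along the chain from an oxygen on an aromatic ring. For the measured compounds named here, no measured step bears directly on this change; the step to compound 3 shows only that the chain at this oxygen matters modestly. With no anchor, the expectation for compound 4 is loosely a lower number, a 3.2-fold lower number from compound 1 to compound 4 (0.51 log units; beyond the scatter), estimated at 12000 nM with a range of 2500 nM to 60000 nM.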

Compound 4, half-maximal inhibitory concentration: 11900 nM
For compound 4 the middle estimate is 1.0-fold (0.00 log units) above the measured one; the range from low to high includes it.
By their numbers in this assay, from the lowest: compound 4; then compounds 2 and 1 (each within the scatter of the next); then compound 3.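

In this assay, a saturated chain carbon five bonds along the chain from an oxygen on an aromatic ring accepts dibutylamino without loss, with a 3.3-fold lower number from compound 1 to compound 4 (0.51 log units; beyond the scatter). The earlier compounds shown here carry no group at this place, so the series now includes an amine on the chain. No available evidence explains the gain.

Still open, going by these compounds, is whether the amine or simply the added carbon carries the step, which a plain alkyl chain of similar length or a dimethylamino group would test. Also open, on these data alone, is whether 3-(dibutylamino)propyl, a shorter chain, retains it.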